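A Butyl Extension Carried onto a Second Core

A few compounds are considered here, and "the series" means these few. Any claim that something is new, unique, unknown or untested is made for them only; others in the source may bear on it.

Of the compounds shown here, three have been measured in an assay on FRT-Jurkat cells for inhibition of nuclear factor NF-kappa-B complex (Homo sapiens), read by flow cytometry, with a stated time of 24 h, tested at 10 uM; a lower number here means less inhibition, a higher number more inhibition at the concentration tested (going by the name of the read-out). Compound 1 `CCCCCc1ccc(Nc2ccc3c(c2)C(=O)N(C2CCC(=O)NC2=O)C3=O)cc1` gives 12%, compound 2 `Cc1ccc(Nc2ccc3c(c2)C(=O)N(C2CCC(=O)NC2=O)C3=O)cc1` gives 5%, and compound 3 `Cc1ccc(Nc2cccc3c2C(=O)N(C2CCC(=O)NC2=O)C3=O)cc1` gives 9%. Compound 2 and compound 1 differ in one place, (butyl in place of hydrogen on a saturated chain carbon bound to an aromatic carbon), and this change produced a number 7 percentage points higher from compound 2 to compound 1 (within the scatter). Compound 3 is built from the same atoms as compound 2 joined differently; the difference between the two cores is not broken down here. For the measured compounds named here, compound 4 `CCCCCc1ccc(Nc2cccc3c2C(=O)N(C2CCC(=O)NC2=O)C3=O)cc1` is still to be measured and differs from compound 3 by butyl in place of hydrogen on a saturated chain carbon bound to an aromatic carbon, the same change, at the same place, as the one that led from compound 2 to compound 1. For compound 4 a step of about a number 6 percentage points higher from compound 3 to compound 4 (within the scatter) is expected, resting on the earlier change that gave a number 7 percentage points higher from compound 2 to compound 1 (within the scatter). Compound 4 is therefore estimated at 15%, most likely between 3% and 28%.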

Compound 4, a percentage reported as inhibition, at one concentration (the size of the read-out at that concentration, not a potency): 23%
Estimate against measurement, compound 4: 8 percentage points below; the range from low to high includes it.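

In this assay, for the compounds shown here, butyl in place of hydrogen gave a number 14 percentage points higher from compound 3 to compound 4 (beyond the scatter), the first step for this change that stands clear of the scatter. Set beside the step on the other core, it does not differ measurably: the same change on two cores in this assay, a number 7 percentage points higher (within the scatter) from compound 2 to compound 1 and a number 14 percentage points higher (beyond the scatter) from compound 3 to compound 4, 7 percentage points apart, within the scatter of two such steps This shows that the change gave comparable results on these two cores, but it does not show that the second core responds more strongly, and a single pair on each core sets no rule for the series.

The compounds shown carry only methyl and pentyl chains. They leave open how the number would move with a longer chain, or with an amine or a carboxylic acid in place of the pentyl.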